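The source may report more compounds than this note shows. Statements on the series, on what has been measured and on what is new or still open speak of the compounds shown alone.

Metabolic stability is one of the first things checked for a new compound, and so far only two numbers are available here. In an ADME assay on cells (Hepatocyte, Mus musculus) for metabolic stability, with a stated time of 30 min (on this read-out higher numbers stand for a more stable compound and lower numbers for a less stable compound), compound 2 `Nc1cc(C(F)(F)F)cc2c(=O)cc(N3CCN(CC4CCC(O)CC4)CC3)sc12` gives 60%. Compound 1 `O=c1cc(N2CCN(CC3CCCCC3)CC2)sc2c(NO)cc(C(F)(F)F)cc12` gives 47.8% in this assay. The gap between them lies beyond the usual scatter, which makes compound 2 the higher of the two.

The next compound, compound 3 `Nc1cc(C(F)(F)F)cc2c(=O)cc(N3CCN(CC4CCCCC4)CC3)sc12`, has hydrogen in place of hydroxy on a saturated ring carbon, so 4-hydroxycyclohexyl becomes cyclohexyl. For the measured compounds named here, no measured pair yet shows this change alone, so any forecast rests on thin evidence. The nearest guide is compound 1, which also carries cyclohexylmethyl, though it differs from compound 3 in another place, and compound 1 gives 47.8%.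

On that basis, a fall is expected, only modestly beyond the scatter, and the estimated step is a number 13 percentage points lower from compound 2 to compound 3 (beyond the scatter). The uncertainty is wide, and a result close to either measured compound would not be surprising. For compound 3, the estimated value in this assay is 47%, within an expected range of 28% to 65%.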

Compound 3, percent of the compound remaining: 69.4%
Compound 3: the middle estimate sits 22.4 percentage points below what was measured, and the stated range ends below it.
By their numbers in this assay, from the lowest: compound 1; then compounds 2 and 3 (each within the scatter of the next).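

In this assay, the exchange of hydroxy for hydrogen on the saturated ring carbon, which turns 4-hydroxycyclohexyl into cyclohexyl, gives a number 9.4 percentage points higher from compound 2 to compound 3 (within the scatter), so this single pair shows no difference at this position that can be told apart from ordinary repeat variation. The exchange of hydroxy for hydrogen on the nitrogen on the aromatic ring gives a number 21.6 percentage points higher from compound 1 to compound 3 (beyond the scatter), a modest step but a real one on this read-out, so the same kind of exchange reads differently at the two places in these two pairs. Nothing measured here explains either step, and each rests on one pair only.

The compounds shown leave open how an amine or a carboxylic acid on that saturated ring carbon would read in this assay, since hydroxy and hydrogen are the only two groups seen there. They also leave open whether a methoxy group on the nitrogen on the aromatic ring would stay close to compound 1 or to compound 3 in this measure of stability.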